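A Phenyl for an Acetoxymethyl on the Side Chain

A few compounds are considered here, and "the series" means these few. Any claim that something is new, unique, unknown or untested is made for them only; others in the source may bear on it.

Compound 1 `CC(=O)OCCOCN1c2ccccc2C(=O)NS1(=O)=O` was tested in a functional assay on CCRF-CEM cells (Homo sapiens) for cytotoxicity; a higher number here means that more compound is tolerated, a lower number that less compound is tolerated. In this assay compound 1 gives only a limit, > 200 ug/mL, so its true value is not known as a number. Compound 2 `CC(=O)OCCOCN1c2ccccc2C(=O)N(Cc2ccccc2)S1(=O)=O` carries a benzyl in place of hydrogen on the amide-type nitrogen of the ring; in this assay compound 2 gives 103 ug/mL. The step of an at least 1.9-fold lower number from compound 1 to compound 2 (0.28 log units; that floor lies within the scatter) is known only from one side, because compound 1 sits at the limit of > 200 ug/mL in this assay, at which 1 of the 2 values shown sits.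

Compound 3 `O=C1NS(=O)(=O)N(COCc2ccccc2)c2ccccc21` differs from compound 1 elsewhere: phenyl in place of acetoxymethyl on a saturated chain carbon bound to an oxygen on a saturated carbon, which, cut one bond further out, reads 2-acetoxyethyl to benzyl. The amide-type nitrogen keeps its hydrogen, as in compound 1. Going by the values given here, no measured step touches this side chain; the only measured step concerns a different nitrogen and reaches no further than the floor set by the limit of compound 1. No shift beyond the scatter can be expected from it. Near the limit seen for compound 1, the estimate for compound 3 is 160 ug/mL, within 60 ug/mL to 350 ug/mL, with a fair chance that this assay again reports only a limit. This means an expected step of an at least 1.2-fold lower number from compound 1 to compound 3 (0.09 log units; that floor lies within the scatter).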

Compound 3, half-maximal cytotoxic concentration: > 200 ug/mL
Compound 3 ended at the assay's limit; the forecaster's own chance of this, stated with the estimate: 45%; middle value at least 1.2-fold (0.09 log units) from the limit.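

In this assay compound 3 gives > 200 ug/mL, which is a limit and not a number. Compound 1 stands at a limit too, so no step from compound 1 to compound 3 can be read: the limit of > 200 ug/mL in this assay, at which 2 of the 3 values shown sit.

The compounds shown leave open whether benzyl in place of 2-acetoxyethyl changes how much compound is tolerated.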